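Pyridin-3-yl to Pyridin-4-yl: What to Expect for Compound 3

The compounds below may be only part of what the source reports. "The series", "measured", "known", "first", "only" and "open" are said of these compounds alone.

Compound 1, `COc1ccccc1C(=O)NCCCNc1nc2cc(C)cc(C)c2cc1C#N`, in an in vitro assay on FRT cells with Cystic fibrosis transmembrane conductance regulator variant F508del (Homo sapiens) as the target, read by fluorescence, with a stated time of 24 h, at 37 degrees C, in the presence of a further agent that is not named here; a lower number here means that less compound is needed, a higher number that more compound is needed for the effect: "not active" (no number reported)
Compound 2, `Cc1cc(C)c2cc(C#N)c(NCCCNC(=O)c3cccnc3)nc2c1`, in this assay: 3000 nM

Among the two measured compounds, compound 2 is the only one with a number in this assay; compound 1 gave no number at all, and so its place relative to compound 2 cannot be judged. Compound 3, `Cc1cc(C)c2cc(C#N)c(NCCCNC(=O)c3ccncc3)nc2c1`, has the same atoms as compound 2 joined differently: pyridin-4-yl in place of pyridin-3-yl on a carbonyl carbon. Among the compounds with values here, no pair of measured compounds shows this change, so there is no measured step to lean on. The expected step from compound 2 to compound 3 is a 1.2-fold higher number from compound 2 to compound 3 (0.07 log units; within the scatter), which means no movement beyond the usual scatter. Compound 3 is therefore estimated at 3500 nM, within a range from 1200 nM to 12000 nM, with a real chance that only a limit is reported.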

Compound 3, half-maximal effective concentration: 8200 nM
Compound 3: middle estimate off by 2.3-fold (0.37 log units), on the low side; low and high end bracket the measured number.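

Swapping pyridin-3-yl for pyridin-4-yl on the carbonyl carbon, with no atom gained or lost, gives a 2.7-fold higher number from compound 2 to compound 3 (0.44 log units; beyond the scatter) in this assay. This position therefore responds to how the same atoms are joined within the ring and not only to which atoms are present, and here pyridin-4-yl is the arrangement that needs more compound for the effect. No measurement shown here explains the shift, so its cause stays unknown.

The two pyridines alone do not show whether pyridin-2-yl or a plain phenyl ring on the same carbonyl carbon would give a lower or a higher number. Also open, going by these compounds, is whether the gap between pyridin-3-yl and pyridin-4-yl would persist with a longer chain linking the amide to the shared core.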